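The source may report more compounds than this note shows. Statements on the series, on what has been measured and on what is new or still open speak of the compounds shown alone.

Compound 1 `COc1ccc(-c2c(S(=O)(=O)c3cccc(C#N)c3)cnc3cc(F)ccc23)cc1` gives 0.92 mL/min.
Compound 2 `COc1cccc(-c2c(S(=O)(=O)c3ccc(C)c(F)c3)cnc3c(F)cccc23)c1` gives 4.02 mL/min.
Compound 3 `N#Cc1cccc(S(=O)(=O)c2cnc3cc(F)ccc3c2-c2cccc(Cl)c2)c1` gives 0.99 mL/min.

In an ADME assay on microsomes from liver (Homo sapiens) for metabolic stability, tested at 2.5 uM (on this read-out lower numbers stand for slow clearance and higher numbers for fast clearance), compound 3 stands second highest of the three numbers: compound 1 lies nearest, a gap within the scatter, and compound 2 lies furthest, a gap beyond the scatter. Within the data shown here, the only single-point step measured, a 1.1-fold higher number from compound 1 to compound 3 (0.03 log units; within the scatter), concerns the aryl group on the core rather than the group on the sulfonyl sulfur, so it speaks only to the general tolerance of this assay toward a swap of one substituted phenyl for another. Compound 4 `O=S(=O)(c1ccc(F)c(F)c1)c1cnc2cc(F)ccc2c1-c1cccc(Cl)c1` differs from compound 3 in this way: 3,4-difluorophenyl in place of 3-cyanophenyl on a sulfonyl sulfur. Among the measured compounds shown here, compound 2 is the only measured compound whose sulfonyl aryl carries fluorine, but it differs from compound 3 in several places at once and so offers no clean step. For the measured compounds named here, with no measured precedent at this position, the step expected in this assay, a 1.2-fold higher number from compound 3 to compound 4 (0.08 log units; within the scatter), is none beyond the scatter. Compound 4 is therefore estimated at 1.2 mL/min, within a range from 0.5 mL/min to 3 mL/min.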

Compound 4, intrinsic clearance in a liver preparation (reported as CLH), per the amount of preparation that the assay uses: 0.38 mL/min
Compound 4: middle estimate off by 3.2-fold (0.50 log units), on the high side; measured number below the stated range.
By their numbers in this assay, from the lowest: compound 4; then compounds 1 and 3 (each within the scatter of the next); then compound 2.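

In this assay, among these compounds, the group on the sulfonyl sulfur can move the number on its own: 3,4-difluorophenyl in place of 3-cyanophenyl gives a 2.6-fold lower number from compound 3 to compound 4 (0.42 log units; beyond the scatter) and so a modest change, whereas the one earlier step, a 1.1-fold higher number from compound 1 to compound 3 (0.03 log units; within the scatter), came from the aryl group on the core and stayed within the scatter. In this pair a low number does not depend on the nitrile, since the rest of the molecule stays the same and the number still falls. Nothing given here bears on why the number falls at this position.

Going by these compounds, it remains open whether one fluorine alone would give the same step, or how a methyl, an amine or a carboxylic acid on this ring would read. Also open, on these data alone, is whether the step holds when 4-methoxyphenyl replaces 3-chlorophenyl on the core.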